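This account rests on a few compounds, and the source may have more. Where it says the series, first, only, none or still open, it means among the compounds named here.

Compound 3 `C=CC(=O)Nc1cc(Nc2nc(C)cc(-c3cn(C)c4ccccc34)n2)c(OC)cc1N(C)CCN(C)C`: 4810 nM
Compound 1 `C=C(F)C(=O)Nc1cc(Nc2nccc(-c3cn(C)c4ccccc34)n2)c(OC)cc1N(C)CCN(C)C`: 4230 nM
Compound 2 `CCC/C=C\C(=O)Nc1cc(Nc2nccc(-c3cn(C)c4ccccc34)n2)c(OC)cc1N(C)CCN(C)C`: 1220 nM

Of the compounds shown here, three built on one shared core have been tested in a functional assay on NCI-H1975 cells (Homo sapiens) for antiproliferative activity, read by MTT assay, with a stated time of 72 h; a lower number here means a stronger inhibitor, a higher number a weaker inhibitor. Compound 3 (`C=CC(=O)Nc1cc(Nc2nc(C)cc(-c3cn(C)c4ccccc34)n2)c(OC)cc1N(C)CCN(C)C`) gives 4810 nM, the highest of the three numbers; compound 1 (`C=C(F)C(=O)Nc1cc(Nc2nccc(-c3cn(C)c4ccccc34)n2)c(OC)cc1N(C)CCN(C)C`) gives 4230 nM, which sits within the usual scatter of compound 3, while compound 2 (`CCC/C=C\C(=O)Nc1cc(Nc2nccc(-c3cn(C)c4ccccc34)n2)c(OC)cc1N(C)CCN(C)C`) gives 1220 nM and stands clearly apart from both.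

The not-yet-measured compound 4 (`CC/C=C\C(=O)Nc1cc(Nc2nc(C)cc(-c3cn(C)c4ccccc34)n2)c(OC)cc1N(C)CCN(C)C`) differs from compound 3 in one place: but-1-en-1-yl in place of vinyl on a carbonyl carbon. Among the compounds with values here, the single measured step that bears on this is a 3.5-fold lower number from compound 1 to compound 2 (0.54 log units; beyond the scatter), where a longer alkenyl chain likewise entered on the carbonyl carbon, though there the group that left was 1-fluoroethenyl rather than vinyl. A modest lowering of the number is therefore expected in this assay, not a large one.

Compound 4 is expected to give 1900 nM in this assay, with a range from 800 nM to 4500 nM. This corresponds to an expected step of a 2.5-fold lower number from compound 3 to compound 4 (0.40 log units; beyond the scatter).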

Compound 4, half-maximal inhibitory concentration: 1990 nM
Beside the measured number, compound 4's estimate is 1.0-fold (0.02 log units) below it, within the range that was stated.
By their numbers in this assay, from the lowest: compounds 2 and 4 (each within the scatter of the next); then compounds 1 and 3 (each within the scatter of the next).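

In this assay, the change from vinyl to but-1-en-1-yl on the carbonyl carbon gives a 2.4-fold lower number from compound 3 to compound 4 (0.38 log units; beyond the scatter). Within the data shown here, this is the first direct reading from plain vinyl, since the earlier step, a 3.5-fold lower number from compound 1 to compound 2 (0.54 log units; beyond the scatter), started from 1-fluoroethenyl and had pent-1-en-1-yl as the entering group, on a different core. Both steps lower the number and none of the steps shown goes against this, but no measurement shown here explains why the longer alkenyl chains have this effect.

Open, from the compounds shown here alone, is whether a saturated propyl chain on the same carbonyl carbon would lower the number as well, which would show whether the double bond is needed. Also open, going by these compounds, is how a dimethylamino group at the end of the but-1-en-1-yl chain would move it.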